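A few compounds are considered here, and "the series" means these few. Any claim that something is new, unique, unknown or untested is made for them only; others in the source may bear on it.

Of the compounds shown here, three have been measured in an ADME assay, at pH 5; a lower number here means that the compound disappears faster, a higher number that the compound lasts longer. Compound 1 (`COc1ccnc(C[S+]([O-])c2nc3cc(OC(F)F)ccc3[nH]2)c1C`) gives 0.17 h, compound 2 (`COc1ccnc(C[S+]([O-])c2nc3cc(OCC(F)(F)F)ccc3[nH]2)c1OC`) gives 7.6 h and compound 3 (`COc1cnc(C[S+]([O-])c2nc3cc(OCC(F)(F)F)ccc3[nH]2)c(C)c1OC`) gives 3.3 h. Compound 3 thus stands second highest of the three, below compound 2 and far above compound 1, with both gaps beyond the scatter.

Compound 4 (`COc1ccnc(C[S+]([O-])c2nc3cc(OCC(F)(F)F)ccc3[nH]2)c1C`) departs from compound 3 by a single change, hydrogen in place of methoxy on an aromatic carbon. Among the compounds with values here, no measured pair shows this change alone, so its size can only be judged indirectly. Compound 4 matches compound 1 in the part of the structure where the change falls, and compound 1 has the lowest number at 0.17 h. A clear drop in this assay, beyond the scatter, is therefore expected, and the estimated step is a 5.5-fold lower number from compound 3 to compound 4 (0.74 log units; beyond the scatter). The half-life expected for compound 4 is 0.6 h, within an estimated range of 0.25 h to 1.5 h.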

Compound 4, half-life in the ADME assay: 0.15 h
Beside the measured number, compound 4's estimate is 4.0-fold (0.60 log units) above it, outside the stated range (below it).
By their numbers in the ADME assay, from the lowest: compounds 4 and 1 (each within the scatter of the next); then compound 3; then compound 2.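

Removing the methoxy group from this carbon, two atoms from the ring nitrogen, carries a large cost in the ADME assay: a 22-fold lower number from compound 3 to compound 4 (1.34 log units; beyond the scatter), while in a physicochemical assay for acid dissociation, compound 3 gives 8.61 and compound 4 gives 8.51, only a number 0.10 log units lower from compound 3 to compound 4 (within the scatter). Methyl in place of methoxy on a different aromatic carbon is also costly in the ADME assay, at a 51-fold lower number from compound 2 to compound 4 (1.70 log units; beyond the scatter), whereas 2,2,2-trifluoroethyl in place of difluoromethyl on the oxygen gives a 1.1-fold lower number from compound 1 to compound 4 (0.05 log units; within the scatter), so the shorter half-lives of this pair go with the ring carrying a single methoxy group and not with the chain on the oxygen. Nothing at hand explains these steps.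

As far as these compounds go, whether an ethoxy group or a chlorine atom on this carbon would keep the longer half-life remains open. So does whether an amine there would.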